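This account rests on a few compounds, and the source may have more. Where it says the series, first, only, none or still open, it means among the compounds named here.

Measured compounds:

Compound 1, `COc1cc(C)ccc1S(=O)(=O)NC1=NCCN1C(=S)SN1CCn2c1nsc2=S`: in a functional assay on KYSE-510 cells (Homo sapiens) for antiproliferative activity, read by crystal violet staining, with a stated time of 96 h (on this read-out higher numbers stand for weaker inhibition of growth and lower numbers for stronger inhibition of growth), compound 1 gives >= 20000 nM, which is a limit of the assay and not a number.

Compound 2, `O=S(=O)(NC1=NCCN1C(=S)SN1CCn2c1nsc2=S)c1ccc(OC(F)(F)F)cc1`: in this assay compound 2 gives >= 20000 nM, again a limit rather than a measured number.

Compound 2 thus stands at the edge of what this assay can report; both known values sit there, as the limit of >= 20000 nM in this assay, at which 2 of the 2 values shown sit, records. Compound 3, `O=S(=O)(NC1=NCCN1C(=S)SN1CCn2c1nsc2=S)c1ccc(Br)cc1`, is the next compound to be measured. It differs from compound 2 in one place: bromo in place of trifluoromethoxy on an aromatic carbon. Going by the values given here, no step between two measured compounds is available to guide the expectation. With both known compounds at a limit, the change is expected to give no step beyond the usual scatter, and compound 3 is expected to stay near that limit as well. Compound 3 is estimated at 20000 nM, with a range from 8000 nM to 50000 nM. This estimate means an expected step of a number no higher from compound 2 to compound 3 (the limit leaves the size open).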

Compound 3, concentration for 50% growth inhibition: >= 20000 nM
Compound 3: only a limit was reported (the forecaster's own chance of this, stated with the estimate: 75%); the middle value sits exactly at the limit.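

Compound 1, compound 2 and compound 3 each give only a limit, not a number, and no step among them can be read in this assay: the limit of >= 20000 nM in this assay, at which 3 of the 3 values shown sit.

The compounds shown leave open how far apart these three truly lie, and whether exchanging these groups changes growth inhibition at all.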